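From Chloro to Trifluoromethyl: the Next Step for Compound 4

The compounds below may be only part of what the source reports. "The series", "measured", "known", "first", "only" and "open" are said of these compounds alone.

Three measured compounds share one core and differ only in the substituent on the benzyl ring. In a functional assay on cells for positive allosteric modulation of G-protein coupled receptor 68 (Homo sapiens), read by a luciferase reporter and cAMP accumulation, with a stated time of 30 min, at pH 6.8 and pH 8.3, in the presence of a further agent that is not named here (a lower number here means a less potent compound, a higher number a more potent compound, by a factor of ten per unit of this negative logarithm), compound 1 `Nc1nc(NCc2cccc(F)c2)nc(-c2ccccc2CO)n1` gives 4.52. Compound 2 `Nc1nc(NCc2ccc(F)cc2)nc(-c2ccccc2CO)n1` gives 3.97, and compound 3 `Nc1nc(NCc2ccc(Cl)cc2)nc(-c2ccccc2CO)n1` gives 5.22, the highest of the three: its nearest neighbour is compound 1, with a number 0.70 log units higher from compound 1 to compound 3 (beyond the scatter), and its furthest is compound 2, with a number 1.25 log units higher from compound 2 to compound 3 (beyond the scatter). Compound 4 `Nc1nc(NCc2ccc(C(F)(F)F)cc2)nc(-c2ccccc2CO)n1` differs from compound 3 by trifluoromethyl in place of chloro on an aromatic carbon. The step that bears most directly on this change is the large rise from compound 2 to compound 3, since both alter the group at the same position; the modest rise from compound 1 to compound 3 also points upward. Compound 4 is therefore expected to show a number 0.28 log units higher from compound 3 to compound 4 (within the scatter), with an estimated value of 5.5 in a range from 4.7 to 6.3.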

Compound 4, negative logarithm of the antagonist equilibrium constant: 5.03
The estimate for compound 4 lay 0.47 log units above the measured number; the range from low to high includes it.
By their numbers in this assay, from the lowest: compound 2; then compound 1; then compounds 4 and 3 (each within the scatter of the next).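

In this assay, at this place, para to a large group, a group of four heavy atoms stands level with chlorine: the change gives a number 0.19 log units lower from compound 3 to compound 4 (within the scatter) and so separates neither compound from the other. The rise over fluoro now holds for a second group, with a number 1.06 log units higher from compound 2 to compound 4 (beyond the scatter) as the step, so it no longer rests on compound 3 alone. No measurement shown accounts for either step. On these data alone, whether a nitrile, a methoxy group or an amine at this place would match chloro and trifluoromethyl stays open. So does how trifluoromethyl would fare at the place fluoro holds in compound 1.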